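Chain Extension in a Hydroxamate Series Against Matrix Metalloproteinase-9

This account rests on a few compounds, and the source may have more. Where it says the series, first, only, none or still open, it means among the compounds named here.

Measured compounds:
Compound 1, `COc1ccc(S(=O)(=O)N2C[C@H](NC(=O)[C@H](CCCN)NC(=O)OC(C)(C)C)C[C@@H]2C(=O)NO)cc1`: 3420 nM
Compound 2, `COc1ccc(S(=O)(=O)N2C[C@H](NC(=O)[C@H](CCCCN)NC(=O)OC(C)(C)C)C[C@@H]2C(=O)NO)cc1`: 27 nM
Compound 3, `COc1ccc(S(=O)(=O)N2C[C@H](NC(=O)[C@@H](N)CCCN)C[C@@H]2C(=O)NO)cc1`: 154 nM

In an assay on isolated protein for inhibition of matrix metalloproteinase-9 (Homo sapiens), read by fluorescence (on this read-out lower numbers stand for stronger inhibition and higher numbers for weaker inhibition), compound 1 gives 3420 nM, while compound 2 gives 27 nM. The step between them, (aminomethyl in place of amino on a saturated chain carbon, four bonds along the chain from an amide-type nitrogen and a carbonyl carbon), produced a 130-fold lower number from compound 1 to compound 2 (2.10 log units; beyond the scatter). The core of compound 3 differs from that of compound 1 by hydrogen in place of tert-butoxycarbonyl on an amine nitrogen, and that step alone produced a 22-fold lower number from compound 1 to compound 3 (1.35 log units; beyond the scatter).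

Compound 4, `COc1ccc(S(=O)(=O)N2C[C@H](NC(=O)[C@@H](N)CCCCN)C[C@@H]2C(=O)NO)cc1`, has not yet been measured in this assay. It differs from compound 3 by aminomethyl in place of amino on a saturated chain carbon, four bonds along the chain from an amine nitrogen and a carbonyl carbon. For the measured compounds named here, this is the same kind of change as the one from compound 1 to compound 2, though not the same: in the earlier pair the altered carbon lies four bonds along the chain from an amide-type nitrogen and a carbonyl carbon, whereas here it lies four bonds along the chain from an amine nitrogen and a carbonyl carbon.

Because a 130-fold lower number from compound 1 to compound 2 (2.10 log units; beyond the scatter) was large, compound 4 is expected to show a comparable but somewhat smaller step, a 31-fold lower number from compound 3 to compound 4 (1.49 log units; beyond the scatter). Compound 4 is therefore estimated at 5 nM, between 1 nM and 30 nM.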

Compound 4, half-maximal inhibitory concentration: 5.7 nM
For compound 4 the middle estimate is 1.1-fold (0.06 log units) below the measured one; low and high end bracket the measured number.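

In this assay the aminomethyl change again lowered the number on the core without tert-butoxycarbonyl, giving a 27-fold lower number from compound 3 to compound 4 (1.43 log units; beyond the scatter), so its direction carried over but its size did not: the same change on two cores in this assay, a 130-fold lower number (2.10 log units; beyond the scatter) from compound 1 to compound 2 and a 27-fold lower number (1.43 log units; beyond the scatter) from compound 3 to compound 4, 4.7-fold (0.67 log units) apart, beyond the scatter of two such steps. Removing the tert-butoxycarbonyl group likewise kept its direction on the longer chain, giving a 4.7-fold lower number from compound 2 to compound 4 (0.68 log units; beyond the scatter), yet the size of this step also changed: the same change on two cores in this assay, a 22-fold lower number (1.35 log units; beyond the scatter) from compound 1 to compound 3 and a 4.7-fold lower number (0.68 log units; beyond the scatter) from compound 2 to compound 4, 4.7-fold (0.67 log units) apart, beyond the scatter of two such steps. All four steps therefore lower the number, but the size of each depends on the other change, so neither can be carried to another core at a fixed size; these two pairs of steps do not show why the sizes differ, or whether the same holds on any other core.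

The compounds shown leave open whether a chain longer than 4-aminobutyl, such as 5-aminopentyl, or a shorter one, such as 2-aminoethyl, would extend the same trend. They also leave open how a carboxylic acid in place of the terminal amine, or an acetyl group in place of tert-butoxycarbonyl, would behave.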